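A few compounds are considered here, and "the series" means these few. Any claim that something is new, unique, unknown or untested is made for them only; others in the source may bear on it.

Measured so far:
compound 1, `Cc1ccc(NC2=CC(=O)c3nc4n(c3C2=O)[C@H]2OC[C@@H](O)[C@H]2OC4)cc1`: 1660 nM
compound 2, `CCCc1ccc(NC2=CC(=O)c3c(nc4n3[C@H]3OC[C@@H](O)[C@H]3OC4)C2=O)cc1`: > 4000 nM

Two compounds of the series have readings in a functional assay on MCF7 cells (Homo sapiens) for inhibition, read by sulforhodamine B assay; a lower number here means a stronger inhibitor, a higher number a weaker inhibitor. Compound 1 gives 1660 nM. As far as these compounds go, compound 2 gives only a limit of the assay, > 4000 nM, and not a number; its true value is unknown beyond that limit, as noted in the limit of > 4000 nM in this assay, at which 1 of the 2 values shown sits. Among the measured compounds shown here, no step between the two measured compounds is counted, so the pair shows only that compound 1 has a number and compound 2 has a limit.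

Compound 3, `O=C1C(Nc2cccc(F)c2)=CC(=O)c2c1nc1n2[C@H]2OC[C@@H](O)[C@H]2OC1`, is not yet measured. It differs from compound 2 in one place: 3-fluorophenyl in place of 4-propylphenyl on an amine nitrogen. The smaller aryl group brings compound 3 nearer in size to compound 1, whose 4-methylphenyl gave a measurable number, than to compound 2. The step from compound 2 to compound 3 is therefore expected to run toward stronger inhibition, by an amount that cannot be fixed from the limit, and the expectation is an at least 2.0-fold lower number from compound 2 to compound 3 (0.30 log units; that floor lies within the scatter). Compound 3 is estimated at 2000 nM, within a range from 700 nM to 6000 nM, with a real chance that the assay again reports only a limit.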

Compound 3, half-maximal inhibitory concentration: > 4000 nM
Compound 3: a limit, no number; the forecaster's own chance of this, stated with the estimate: 30%; middle value at least 2.0-fold (0.30 log units) away from the limit.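

In this assay compound 3 gives > 4000 nM, a limit and not a number. Compound 2 also gives only a limit, so no step from compound 2 to compound 3 can be read: the limit of > 4000 nM in this assay, at which 2 of the 3 values shown sit.

The compounds shown leave open how 3-fluorophenyl and 4-propylphenyl on the amine nitrogen truly differ in this series.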